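The source may report more compounds than this note shows. Statements on the series, on what has been measured and on what is new or still open speak of the compounds shown alone.

Compound 1 `C=C(Br)C(=O)Nc1cccc(/C=C2\SC(=O)N(Cc3cccc(F)c3)C2=O)c1` carries a (1-bromoethenyl)carbonyl group on its aromatic amine nitrogen and a 3-fluorobenzyl group on the ring nitrogen of its core. In a functional assay on L1210 cells (Mus musculus) for cytotoxicity, read by cell counting, with a stated time of 2 days (a lower number here means a stronger inhibitor, a higher number a weaker inhibitor), compound 1 gives 590 nM, the lowest of the three numbers measured. Compound 2 `Nc1cccc(/C=C2\SC(=O)N(Cc3cccc(F)c3)C2=O)c1`, in which that amide group is replaced by hydrogen, gives 199000 nM in this assay, and the step is a 340-fold higher number from compound 1 to compound 2 (2.53 log units; beyond the scatter). Compound 3 `Nc1ccc(/C=C2\SC(=O)N(Cc3ccc(Cl)cc3)C2=O)cc1` gives 37000 nM in this assay; it differs from compound 1 in more than one place, so its number serves only as a further point of reference.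

Compound 4 `C=C(Br)C(=O)Nc1cccc(/C=C2\SC(=O)N(Cc3ccc(F)cc3)C2=O)c1` differs from compound 1 by 4-fluorophenyl in place of 3-fluorophenyl on a saturated chain carbon bound to an amide-type nitrogen in a ring. Within the data shown here, no measured pair isolates this change. Among the measured compounds shown here, the single step on record concerns the amide and says nothing about the fluorine on the benzyl ring, and compounds 2 and 3 differ from each other in several places at once. With nothing pointing either way, the change is expected to leave the number close to that of compound 1, with no step beyond the scatter, as a 1.0-fold higher number from compound 1 to compound 4 (0.01 log units; within the scatter). Compound 4 is therefore estimated at 600 nM, within a range from 200 nM to 1800 nM.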

Compound 4, half-maximal inhibitory concentration: 680 nM
Compound 4: middle estimate off by 1.1-fold (0.05 log units), on the low side, and the stated range covers the measured number.
By their numbers in this assay, from the lowest: compounds 1 and 4 (each within the scatter of the next); then compound 3; then compound 2.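

Among these compounds, exchanging 3-fluorobenzyl for 4-fluorobenzyl gives the first reading of a change on a saturated chain carbon bound to an amide-type nitrogen in a ring, and in this assay it amounts to a 1.2-fold higher number from compound 1 to compound 4 (0.06 log units; within the scatter). Among the compounds shown here, the only step available earlier concerned the (1-bromoethenyl)carbonyl group on the aromatic amine nitrogen, a 340-fold higher number from compound 1 to compound 2 (2.53 log units; beyond the scatter), and it said nothing about the benzyl ring; this new step shows that, for these two fluorine placements, compound 1 and compound 4 cannot be told apart in this read-out, with the amide group in place. No independent data bear on why these two placements read alike.

The compounds shown leave open whether fluorine matters here at all, as an unsubstituted benzyl group, a 4-methoxybenzyl group or a longer chain such as 2-phenylethyl on the same nitrogen could behave differently with the amide group kept. They also leave open whether 4-chlorobenzyl would match 4-fluorobenzyl with that amide group present, as compound 3 differs from compound 4 in more than one place and serves only as a distant point of reference.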